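The compounds below may be only part of what the source reports. "The series", "measured", "known", "first", "only" and "open" are said of these compounds alone.

Measured in a physicochemical assay for solubility, in phosphate buffer, at pH 6.5; a lower number here means a less soluble compound, a higher number a more soluble compound:
Compound 1 `C=C[C@@H]1C[C@]1(NC(=O)[C@@H]1C[C@@H](Oc2nccc3cc(OC)ccc23)CN1C(=O)[C@@H](NC(=O)NC(C)(C)C)C(C)(C)C)C(=O)NS(=O)(=O)C1CC1`: 13 ug/mL
Compound 2 `C=C[C@@H]1C[C@]1(NC(=O)[C@@H]1C[C@@H](Oc2nccc3cc(OC)ccc23)CN1C(=O)[C@@H](NC(=O)N[C@@H](CC)COC)C(C)(C)C)C(=O)NS(=O)(=O)C1CC1`: 500 ug/mL
Compound 3 `C=C[C@@H]1C[C@]1(NC(=O)[C@@H]1C[C@@H](Oc2nccc3cc(OC)ccc23)CN1C(=O)[C@@H](NC(=O)N[C@H](COC)C(C)C)C(C)(C)C)C(=O)NS(=O)(=O)C1CC1`: 570 ug/mL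

Compound 2 stands at the upper end of this short set together with compound 3, the two being level within the scatter, and far from compound 1. The next compound is compound 4 `C=C[C@@H]1C[C@]1(NC(=O)[C@@H]1C[C@@H](Oc2nccc3cc(OC)ccc23)CN1C(=O)[C@@H](NC(=O)N[C@H](COC)[C@@H](C)CC)C(C)(C)C)C(=O)NS(=O)(=O)C1CC1`, which differs from compound 2 as follows: ethyl in place of hydrogen on a saturated chain carbon bound to two saturated chain carbons. This places ethyl in place of hydrogen on a saturated chain carbon bound to two saturated chain carbons. Among the compounds with values here, the nearest precedent is methyl in place of hydrogen at the same kind of carbon, which gave a 1.1-fold higher number from compound 2 to compound 3 (0.06 log units; within the scatter). That single step is the main guide, and a loose one, since ethyl is not methyl. The large steps, a 38-fold higher number from compound 1 to compound 2 (1.59 log units; beyond the scatter) and a 44-fold higher number from compound 1 to compound 3 (1.64 log units; beyond the scatter), both replace tert-butyl and bear on this change only indirectly. No step beyond the scatter is therefore expected in this assay, and the expected step is a 1.1-fold lower number from compound 2 to compound 4 (0.05 log units; within the scatter). For compound 4 the estimate is 450 ug/mL, with an expected range of 200 ug/mL to 900 ug/mL.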

Compound 4, solubility: 326 ug/mL
Compound 4: middle estimate off by 1.4-fold (0.14 log units), on the high side; measured number inside the range.
By their numbers in this assay, from the lowest: compound 1; then compounds 4, 2 and 3 (each within the scatter of the next).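

In this assay this carbon carries more than a methyl without a step beyond the scatter: ethyl in place of hydrogen on a saturated chain carbon bound to two saturated chain carbons stays within it (a 1.5-fold lower number from compound 2 to compound 4 (0.19 log units; within the scatter)), and so does methyl in place of hydrogen on a saturated chain carbon, three bonds along the chain from an amide-type nitrogen (a 1.7-fold lower number from compound 3 to compound 4 (0.24 log units; within the scatter)). The large step away from tert-butyl also survives this longer branch (a 25-fold higher number from compound 1 to compound 4 (1.40 log units; beyond the scatter)), as it does in compound 2 and compound 3. Nothing at hand accounts for the size of these steps.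

The compounds shown do not separate the part played by the methoxymethyl group from the loss of tert-butyl. As far as these compounds go, how a longer chain at this carbon, or an amine in place of the methoxy group, would read in this assay also stays open.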